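The source may hold more compounds than are shown below. What is called first, only, known or untested is meant among the compounds shown, and "the series" means these compounds.

Measured compounds:
- compound 1, `O=C(Nc1cccc(-c2ccccc2C(F)(F)F)c1)C(Cl)Cl` — 7500 nM
- compound 2, `O=C(Nc1cccc(-c2ccc(F)cc2)c1)C(Cl)Cl` — 7840 nM
- compound 3, `COc1cccc(-c2cc(NC(=O)C(Cl)Cl)cc(-c3cccc(OC)c3)c2)c1` — 9400 nM

The three measured compounds share a dichloroacetamide on an aryl ring that carries a second aromatic ring; they differ in the substitution of that second ring. In a functional assay on A549 cells (Homo sapiens) for cytotoxicity, read by MTT assay, with a stated time of 68 h (on this read-out higher numbers stand for weaker inhibition and lower numbers for stronger inhibition), compound 1 gives 7500 nM, compound 2 gives 7840 nM and compound 3 gives 9400 nM. Compound 2 stands second highest of the three numbers, but its gap to compound 1 and its gap to compound 3 both lie within the usual scatter, so the three values cannot be ordered; nothing separates them.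

Compound 4, `O=C(Nc1cccc(-c2ccccc2)c1)C(Cl)Cl`, has not yet been measured in this assay. The change from compound 2 is hydrogen in place of fluoro on an aromatic carbon, the hydrogen entering on an aromatic carbon of a six-membered aromatic ring of carbon only, para to a large group. Going by the values given here, no step between measured compounds bears on this change directly. Given that the substituted variants compound 1, compound 2 and compound 3 all sit together within the scatter, no step beyond the scatter is expected in either direction, and the expected step of a 1.1-fold higher number from compound 2 to compound 4 (0.04 log units; within the scatter) is set at about nothing. The estimate for compound 4 in this assay is 8500 nM, with a range from 4000 nM to 18000 nM.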

Compound 4, half-maximal inhibitory concentration: 8900 nM
The estimate for compound 4 lay 1.0-fold (0.02 log units) below the measured number; the range from low to high includes it.
By their numbers in this assay, from the lowest: compounds 1, 2, 4 and 3 (each within the scatter of the next).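

In this assay hydrogen in place of fluoro, on an aromatic carbon para to a large group, gives a 1.1-fold higher number from compound 2 to compound 4 (0.06 log units; within the scatter) and hydrogen in place of trifluoromethyl gives a 1.2-fold higher number from compound 1 to compound 4 (0.07 log units; within the scatter) on the second ring. Compound 4 supplies the reference with no substituent on that ring that the earlier compounds lacked, and neither fluoro nor trifluoromethyl separates from hydrogen, so neither group is shown to matter for this read-out. No measurement at hand explains this flat result.

The compounds shown leave open whether a group of another kind on the second ring, such as an amine or a carboxylic acid, would give a step beyond the scatter. As far as these compounds go, all four compounds also carry the dichloroacetamide, so what happens to the number when that group gives way to a plain acetamide or a longer chain remains unknown.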